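Swapping an amide for a urea: expected cell toxicity

The source may report more compounds than this note shows. Statements on the series, on what has been measured and on what is new or still open speak of the compounds shown alone.

Measured compounds:
compound 1 `COc1cc(-c2nn(-c3cccc(NC(=O)c4ccc(Cl)c(C(F)(F)F)c4)c3)cc2-c2ccncc2)ccc1Cl` — 24700 nM
compound 2 `O=C(Nc1cccc(-n2cc(-c3ccncc3)c(-c3ccc(Cl)c(O)c3)n2)c1)Nc1cc(C(F)(F)F)cc(C(F)(F)F)c1` — 15600 nM

In a functional assay on MDA-MB-435 cells (Homo sapiens) for inhibition, read by sulforhodamine B assay, with a stated time of 48 h (on this read-out lower numbers stand for higher toxicity in this test and higher numbers for lower toxicity in this test), compound 1 gives 24700 nM, the higher of the two numbers, and compound 2 gives 15600 nM. The two values lie within the scatter of each other, so nothing separates them. Compound 3 `COc1cc(-c2nn(-c3cccc(NC(=O)Nc4cccc(C(F)(F)F)c4)c3)cc2-c2ccncc2)ccc1Cl` has not been measured. It differs from compound 1 in one place: (3-(trifluoromethyl)phenyl)amino in place of 4-chloro-3-(trifluoromethyl)phenyl on a carbonyl carbon. Within the data shown here, no pair of measured compounds isolates this change, and compound 2, which also carries a urea-type linkage, differs from compound 1 elsewhere too, so it cannot serve as a guide. With both measured numbers close together, the step from compound 1 to compound 3 is expected to be small, a 1.4-fold lower number from compound 1 to compound 3 (0.14 log units; within the scatter), with no change beyond the scatter. Compound 3 is therefore estimated at 18000 nM, within a range of 6000 nM to 50000 nM.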

Compound 3, concentration lethal to 50% of the cells: 8070 nM
Beside the measured number, compound 3's estimate is 2.2-fold (0.35 log units) above it; low and high end bracket the measured number.
By their numbers in this assay, from the lowest: compounds 3, 2 and 1 (each within the scatter of the next, the first and the last beyond it).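

In this assay, the change gives a 3.1-fold lower number from compound 1 to compound 3 (0.49 log units; beyond the scatter), so the group on this carbonyl carbon can move the number beyond the scatter, and here the move is towards higher toxicity in this test. The two earlier compounds, which differ in more than one place, could not show this. The step also combines two changes, as the ring loses its chlorine and an amino nitrogen enters on the carbonyl carbon, and nothing at hand gives a reason for the shift.

Which of these two changes accounts for the step remains open, and a (4-chloro-3-(trifluoromethyl)phenyl)amino group on the same carbonyl carbon would separate them. How a methylene in place of that amino nitrogen would read in this assay is open as well.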